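The source may report more compounds than this note shows. Statements on the series, on what has been measured and on what is new or still open speak of the compounds shown alone.

Measured compounds:
compound 1 `O=c1[nH]nc2n(c1=O)CCN2c1ccccc1` gives 0% in a functional assay on T47D cells (Homo sapiens) for cytotoxicity, with a stated time of 72 h, tested at 10 ug/mL; a lower number here means a weaker effect, a higher number a stronger effect of the compound at the concentration tested
compound 2 `Cc1ccccc1N1CCn2c1n[nH]c(=O)c2=O` gives 0% in this assay
compound 3 `Cc1ccc(N2CCn3c2n[nH]c(=O)c3=N)cc1` gives 0% in this assay

The step from compound 2 to compound 1 is hydrogen in place of methyl on an aromatic carbon and makes no change at the digits printed from compound 2 to compound 1 (within the scatter). The difference between the core of compound 3 and the core of compound 2 is not broken down here. Compound 4 `N=c1c(=O)[nH]nc2n1CCN2c1ccccc1` is not yet measured; it differs from compound 3 by hydrogen in place of methyl on an aromatic carbon. This is the same kind of change as that from compound 2 to compound 1, but the place is para to a large group rather than ortho to a large group. Because compound 2 and compound 1 show no change at the digits printed from compound 2 to compound 1 (within the scatter), and compound 3 gives 0%, the expected step is no change at the digits printed from compound 3 to compound 4 (within the scatter). Compound 4 is therefore estimated at 0%, between 0% and 10%.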

Compound 4, a percentage reported as inhibition, at one concentration (the size of the read-out at that concentration, not a potency): 0%
For compound 4 middle estimate and measured number coincide at the digits printed, within the range that was stated.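

In this assay, hydrogen in place of methyl on the aromatic ring gives no change at the digits printed from compound 3 to compound 4 (within the scatter), and the earlier pair on the other core reads the same: the same change on two cores in this assay, no change at the digits printed (within the scatter) from compound 2 to compound 1 and no change at the digits printed (within the scatter) from compound 3 to compound 4, 0 percentage points apart, within the scatter of two such steps. Within these four compounds, then, the change carries from one core to the other with the same outcome. It does not show that the change is without consequence in active compounds: compound 4 gives 0%, the other three read the same, and a read-out with no inhibition leaves no effect for the change to reduce.

Still open, from the compounds shown here alone, is whether another group on the aromatic ring, such as an amine, a carboxylic acid or a longer chain, would give any inhibition in this assay. Also open, going by these compounds, is whether swapping methyl for hydrogen would remain without effect on a compound that does inhibit.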